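A few compounds are considered here, and "the series" means these few. Any claim that something is new, unique, unknown or untested is made for them only; others in the source may bear on it.

In a functional assay on HeLa cells (Homo sapiens) for cytotoxicity, read by MTT assay, with a stated time of 48 h (on this read-out higher numbers stand for weaker inhibition and lower numbers for stronger inhibition), compound 3 `CCOC(=O)c1c(-c2cc3ccc(OCC=C(C)C)cc3oc2=O)nn(-c2cccc(C)c2)c1C(=O)OCC` gives 150000 nM, the highest of the three numbers recorded here. Compound 2 `CCOC(=O)c1c(-c2cc3ccc(OCC=C(C)C)cc3oc2=O)nn(-c2ccccc2)c1C(=O)OCC` stands nearest to it with 130000 nM, and the step of a 1.2-fold higher number from compound 2 to compound 3 (0.06 log units; within the scatter) lies within the scatter, so the two cannot be told apart. Compound 1 `CCOC(=O)c1c(-c2cc3ccccc3oc2=O)nn(-c2cccc(Cl)c2)c1C(=O)OCC` stands furthest away with 22000 nM, a lower number than compound 3 by more than the scatter; compound 1, however, differs from compound 3 in two places at once, in the group on the pendant phenyl ring and in the chain that compounds 2 and 3 carry and compound 1 lacks, so its value alone cannot be attributed to either change.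

Compound 4 `CCOC(=O)c1c(-c2cc3ccc(OCC=C(C)C)cc3oc2=O)nn(-c2cccc(Cl)c2)c1C(=O)OCC` differs from compound 3 by chloro in place of methyl on an aromatic carbon, which read one bond further out is 3-methylphenyl becoming 3-chlorophenyl, at a position meta to a large group. Going by the values given here, the only measured single change on that ring, a 1.2-fold higher number from compound 2 to compound 3 (0.06 log units; within the scatter), stayed within the scatter, and no measured step exchanges methyl for chloro on its own. The expected change in this assay is therefore a 1.7-fold lower number from compound 3 to compound 4 (0.22 log units; within the scatter), a modest movement toward lower numbers that may not exceed the scatter. Compound 4 is estimated at 90000 nM, with a range from 35000 nM to 230000 nM.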

Compound 4, half-maximal inhibitory concentration: 110000 nM
For compound 4 the middle estimate is 1.2-fold (0.09 log units) below the measured one; the measured number falls inside the stated range.
By their numbers in this assay, from the lowest: compound 1; then compounds 4, 2 and 3 (each within the scatter of the next).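

At this place on the six-membered aromatic ring, meta to a large group, chloro and methyl cannot be told apart in this assay: the exchange gives a 1.4-fold lower number from compound 3 to compound 4 (0.13 log units; within the scatter), and chloro against hydrogen gives a 1.2-fold lower number from compound 2 to compound 4 (0.07 log units; within the scatter), so hydrogen, methyl and chloro all read alike among these compounds. The new compound also supplies a pair differing in one place only, with 3-chlorophenyl held constant, and the (3-methylbut-2-en-1-yl)oxy group in place of hydrogen gives a 5.0-fold higher number from compound 1 to compound 4 (0.70 log units; beyond the scatter), so on this single pair the move to a higher number goes with that chain and not with the group on the ring. Nothing given here accounts for either result.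

As far as these compounds go, whether an amine or a carboxylic acid at the same ring position would stand apart from hydrogen, methyl and chloro remains open, since all three substituents compared there are small and uncharged. Also open, from the compounds shown here alone, is whether the step seen with the (3-methylbut-2-en-1-yl)oxy group would hold on the phenyl or 3-methylphenyl compounds, and whether a longer chain or a plain methoxy group in its place would give a step of the same size.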